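Cytotoxicity notes on a piperidine amide series

A few compounds are considered here, and "the series" means these few. Any claim that something is new, unique, unknown or untested is made for them only; others in the source may bear on it.

Measured so far:
compound 1 `Cc1nc(-c2cccc(C(=O)N3CCCC(C(=O)Nc4ccc(Cl)cc4)C3)c2)cs1` — 1%
compound 2 `O=C(c1ccccc1)c1cccc(C(=O)N2CCCC(C(=O)Nc3ccc(Cl)cc3)C2)c1` — 0%
compound 3 `CCN(CC)S(=O)(=O)c1cccc(C(=O)N2CCCC(C(=O)Nc3ccc(Cl)cc3)C2)c1` — 0%

In an ADME assay on PC-3 cells (Homo sapiens) for cytotoxicity, read by WST assay, tested at 100 uM (a lower number here means less inhibition, a higher number more inhibition at the concentration tested (going by the name of the read-out)), compound 3 stands level with compound 2 at the digits shown, the two together the lowest of three numbers, and compound 1 sits nearest above it by a number 1 percentage points lower from compound 1 to compound 3 (within the scatter). All three numbers lie within the usual scatter of one another.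

Compound 4 `CS(=O)(=O)c1cccc(C(=O)N2CCCC(C(=O)Nc3ccc(Cl)cc3)C2)c1` differs from compound 3 by methyl in place of diethylamino on a sulfonyl sulfur, that is, diethylsulfamoyl to methylsulfonyl. Within the data shown here, no measured step changes the sulfonyl substituent itself; the bearing steps are a number 1 percentage points lower from compound 1 to compound 3 (within the scatter) and no change at the digits printed from compound 2 to compound 3 (within the scatter), both within the scatter, as is a number 1 percentage points lower from compound 1 to compound 2 (within the scatter). A step of a number 1 percentage points higher from compound 3 to compound 4 (within the scatter) is therefore expected, none beyond the scatter. For compound 4 in this assay the estimate is 1%, with a range from -9% to 11%.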

Compound 4, a percentage reported as inhibition, at one concentration (the size of the read-out at that concentration, not a potency): 2%
For compound 4 the middle estimate is 1 percentage points below the measured one; measured number inside the range.
By their numbers in this assay, from the lowest: compounds 2, 3, 1 and 4 (each within the scatter of the next).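

In this assay, the substituent on the sulfonyl sulfur itself now varies: a number 2 percentage points higher from compound 3 to compound 4 (within the scatter) with methyl in place of diethylamino, so the smaller group stays level with the larger one. Comparing methylsulfonyl with the other groups on the aromatic carbon, a number 2 percentage points higher from compound 2 to compound 4 (within the scatter) and a number 1 percentage points higher from compound 1 to compound 4 (within the scatter) both leave it level with benzoyl and 2-methyl-1,3-thiazol-4-yl. Thus compound 1, compound 2, compound 3 and compound 4 all read alike. As far as these compounds go, whether an amine or a carboxylic acid on this aromatic carbon would read differently stays open. No evidence on hand bears on why these groups read alike.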